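This account rests on a few compounds, and the source may have more. Where it says the series, first, only, none or still open, it means among the compounds named here.

In an ADME assay on microsomes from liver (Homo sapiens) for metabolic stability, with a stated time of 10 min (a lower number here means that less of the compound is left, a higher number that more of the compound is left), the measured compounds are:
- compound 1 `COc1ccc(Nc2nc(Cl)cn([C@H](C)C3CC3)c2=O)c(C)n1` gives 60% 
- compound 2 `COc1cc(C)c(Nc2nc(Cl)cn([C@H](C)C3CC3)c2=O)c(C)n1` gives 81% 
- compound 3 `COc1nc(C)c(Nc2nc(Cl)cn([C@H](C)C3CC3)c2=O)cc1C` gives 55% 

Compound 3 at 55% sits within the scatter of compound 1 at 60% and clearly under compound 2 at 81% on this scale. Compound 4 `Cc1cc(Nc2nc(Cl)cn([C@H](C)C3CC3)c2=O)c(C)nc1N1CCCC1` has not been measured yet. It carries pyrrolidin-1-yl in place of methoxy on an aromatic carbon and is otherwise the same as compound 3.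

Among the measured compounds shown here, no measured step touches the methoxy group, so the evidence is indirect. Methyl in place of hydrogen on an aromatic carbon gave a number 21 percentage points higher from compound 1 to compound 2 (beyond the scatter) in one case and a number 5 percentage points lower from compound 1 to compound 3 (within the scatter) in another. A single swap in this series can therefore move the number modestly or not at all. A modest step is expected in this assay on that basis, and its downward direction is a judgement that the data do not settle. The expected change is a number 15 percentage points lower from compound 3 to compound 4 (beyond the scatter) with wide uncertainty. Compound 4 is estimated at 40% with a range from 15% to 65% in this test.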

Compound 4, percent of the compound remaining: 26%
Estimate against measurement, compound 4: 14 percentage points above; the range from low to high includes it.
By their numbers in this assay, from the lowest: compound 4; then compounds 3 and 1 (each within the scatter of the next); then compound 2.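

In this assay, putting pyrrolidin-1-yl in place of methoxy on this aromatic carbon, next to the ring nitrogen, gives a number 29 percentage points lower from compound 3 to compound 4 (beyond the scatter). Compounds 1, 2 and 3 all carry methoxy here, so they could not show that the group on this carbon matters; this step shows that it does, and that here the larger group with a ring goes with less compound left. Nothing measured here explains the drop.

Among the compounds shown, pyrrolidin-1-yl is the only replacement for methoxy, so it stays open how a dimethylamino group, a longer ethoxy chain or a morpholine ring would fare at this carbon. Also open, going by these compounds, is whether the same swap would lower the number for compound 2, which stands at 81% with its methyl groups placed differently.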